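Amides of a difluorobiphenyl acetoxy acid in the writhing test

This account rests on a few compounds, and the source may have more. Where it says the series, first, only, none or still open, it means among the compounds named here.

Measured compounds and their values:
Compound 1 `CC(=O)Oc1ccc(-c2ccc(F)cc2F)cc1C(=O)O`: 0%
Compound 2 `CC(=O)Oc1ccc(-c2ccc(F)cc2F)cc1C(=O)NC1CCCCC1`: 15.6%
Compound 3 `CC(=O)Oc1ccc(-c2ccc(F)cc2F)cc1C(=O)NCc1ccccc1`: 16.6%

In a functional assay on the whole organism (strain Kunming) for inhibition, with Mus musculus as the target, in the writhing test, at a dose of 40 mg/kg by the oral route (a lower number here means less inhibition, a higher number more inhibition at the dose given (going by the name of the read-out)), compound 3 gives the highest of the three numbers, though compound 2 lies within the scatter of it; only compound 1 sits beyond the scatter, as the step of a number 16.6 percentage points higher from compound 1 to compound 3 (beyond the scatter) shows. Compound 4 `CC(=O)Oc1ccc(-c2ccc(F)cc2F)cc1C(=O)Nc1ccccc1` differs from compound 3 by phenyl in place of benzyl on an amide-type nitrogen. Going by the values given here, no measured step covers this change directly. The nearest comparison is a number 1 percentage points higher from compound 2 to compound 3 (within the scatter), a change on the same amide-type nitrogen that stayed within the scatter, while the two amide-forming steps a number 15.6 percentage points higher from compound 1 to compound 2 (beyond the scatter) and a number 16.6 percentage points higher from compound 1 to compound 3 (beyond the scatter) were both modest and alike. Compound 4 is therefore expected to give 17% (range 5% to 30%), a step of a number 0.4 percentage points higher from compound 3 to compound 4 (within the scatter) that is expected to stay within the scatter.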

Compound 4, a percentage reported as inhibition, in the whole organism at one dose (the size of the read-out at that dose, not a potency): 8.9%
Estimate against measurement, compound 4: 8.1 percentage points above, and the stated range covers the measured number.
By their numbers in this assay, from the lowest: compounds 1, 4, 2 and 3 (each within the scatter of the next, the first and the last beyond it).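

In this assay, phenyl in place of benzyl on the amide-type nitrogen stays within the scatter, with a number 7.7 percentage points lower from compound 3 to compound 4 (within the scatter) and likewise a number 6.7 percentage points lower from compound 2 to compound 4 (within the scatter) among the amides. Yet the anilino amide, unlike compounds 2 and 3, is not separated from the acid, with a number 8.9 percentage points higher from compound 1 to compound 4 (within the scatter) within the scatter, so amide formation at this carbonyl does not clear the scatter for every amine. No measurement here bears on the reason for this. Open, from the compounds shown here alone, is whether phenethyl or pyridylmethyl on this nitrogen would clear compound 1 by more than compounds 2 and 3 do.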